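Trans-cinnamate acid in place of a second guanidinobutyl amide

A few compounds are considered here, and "the series" means these few. Any claim that something is new, unique, unknown or untested is made for them only; others in the source may bear on it.

Compound 1 `N=C(N)NCCCCNC(=O)/C=C/c1ccc2c(c1)[C@H](C(=O)NCCCCNC(=N)N)[C@@H](c1ccc(O)cc1)O2` is the higher of the two numbers seen so far in a functional assay on Caudal artery for antagonist activity at Alpha-1A adrenergic receptor (Rattus norvegicus) (on this read-out higher numbers stand for weaker inhibition and lower numbers for stronger inhibition), where compound 1 gives 19300000 nM. Its stereoisomer compound 2 `N=C(N)NCCCCNC(=O)/C=C/c1ccc2c(c1)[C@H](C(=O)NCCCCNC(=N)N)[C@H](c1ccc(O)cc1)O2` gives 4900000 nM in this assay, and the step of a 3.9-fold lower number from compound 1 to compound 2 (0.60 log units; beyond the scatter) is the only measured one; the difference there is purely one of drawn configuration the fact that one of compounds 1 and 2 is drawn with a defined configuration and the other without, at the place where they differ and says nothing about replacing a side chain. Compound 3 `N=C(N)NCCCCNC(=O)[C@H]1c2cc(/C=C/C(=O)O)ccc2O[C@@H]1c1ccc(O)cc1` differs from compound 1 by one oxygen atom in place of a group of 9 heavy atoms (5 carbon, 4 nitrogen; no ring), on a carbonyl carbon, leaving a free acid on the chain. Among the compounds with values here, no measured pair covers this kind of change, so there is nothing to scale an expectation from. The working estimate for compound 3 is therefore a step of about a 1.3-fold higher number from compound 1 to compound 3 (0.11 log units; within the scatter), that is no change beyond the scatter, with a wide band to reflect the absence of any guiding step. Compound 3 is expected to give roughly 25000000 nM in this assay, within 5000000 nM to 120000000 nM.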

Compound 3, half-maximal inhibitory concentration: > 100000000 nM
Compound 3 ended at the assay's limit; the forecaster's own chance of this, stated with the estimate: 30%; at least 4.0-fold (0.60 log units) between middle value and limit.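

Exchanging the group of 9 heavy atoms on the carbonyl carbon for hydroxy gives an at least 5.1-fold higher number from compound 1 to compound 3 (0.71 log units; beyond the scatter), so this position responds to a change of substituent and not only to drawn configuration, the sole difference in the earlier step, a 3.9-fold lower number from compound 1 to compound 2 (0.60 log units; beyond the scatter). The change weakens inhibition, and the direction is clear from this single pair. From the compounds shown here alone, compound 3 reads > 100000000 nM in this assay, which is a limit of the assay and not a number, so the true size of the step stays unknown.

Open, going by these compounds, is whether a primary amine or a longer chain ending in a guanidine on this carbonyl carbon would keep the inhibition of compound 1. Also open, on these data alone, is whether the same exchange for hydroxy on compound 2 gives a comparable step.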